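Methoxy in place of cyano: a half-life estimate

The compounds below may be only part of what the source reports. "The series", "measured", "known", "first", "only" and "open" are said of these compounds alone.

Measured in an in vitro ADME assay on microsomes from liver (Simiiformes); on this read-out lower numbers stand for a shorter-lived compound and higher numbers for a longer-lived compound:
Compound 1 `Cc1cc(CCCOc2c(C)cc(-c3noc(C)n3)cc2C)on1`: 0.45 h
Compound 2 `Cc1cc(CCCOc2c(C)cc(-c3noc(CF)n3)cc2C)on1`: 0.233 h
Compound 3 `Cc1cc(CCCOc2c(C)cc(-c3noc(C#N)n3)cc2C)on1`: 0.283 h

Compound 3 has no clear rank of its own among the three. The gaps that place it are a 1.2-fold higher number from compound 2 to compound 3 (0.08 log units; within the scatter) and a 1.6-fold lower number from compound 1 to compound 3 (0.20 log units; within the scatter).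

The next compound, compound 4 `COc1nc(-c2cc(C)c(OCCCc3cc(C)no3)c(C)c2)no1`, has not yet been measured. It carries methoxy in place of cyano on an aromatic carbon, so that 5-cyano-1,2,4-oxadiazol-3-yl becomes 5-methoxy-1,2,4-oxadiazol-3-yl: methoxy in place of cyano on an aromatic carbon.

The measured steps that bear on this change all fall at the same carbon or on the group it bears. Besides the two gaps above, there is a 1.9-fold lower number from compound 1 to compound 2 (0.29 log units; within the scatter). Going by the values given here, none of them involves methoxy, so the data hold no direct precedent for the new group. Still, methyl, fluoromethyl and cyano have so far given values within the scatter of one another. No step beyond the scatter is therefore expected here, and the estimated step is a 1.1-fold higher number from compound 3 to compound 4 (0.03 log units; within the scatter), in no firm direction.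

The estimated value in this assay for compound 4 is 0.3 h, with an expected range from 0.15 h to 0.6 h.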

Compound 4, half-life: 0.55 h
Estimate against measurement, compound 4: 1.8-fold (0.26 log units) below; measured number inside the range.
By their numbers in this assay, from the lowest: compounds 2, 3, 1 and 4 (each within the scatter of the next, the first and the last beyond it).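

In this assay, this position now shows its first step beyond the scatter, a 2.4-fold higher number from compound 2 to compound 4 (0.37 log units; beyond the scatter), a modest one that comes with methoxy in place of fluoromethyl, so the carbon is not wholly indifferent to the group it bears. Methoxy nevertheless stays within the scatter of the other two groups, at a 1.9-fold higher number from compound 3 to compound 4 (0.29 log units; within the scatter) and a 1.2-fold higher number from compound 1 to compound 4 (0.09 log units; within the scatter), which means that compound 4 stands apart only from compound 2 and that the whole separation rests on this one pair. No measurement shown here offers an explanation for that single gap.

The compounds shown leave open whether a longer chain on the oxygen, such as ethoxy, or an amine or a trifluoromethyl group on this same aromatic carbon would stay with methoxy or fall with fluoromethyl. Going by these compounds, all four compounds also share the rest of the structure and a single read-out, so it remains open whether the gap between methoxy and fluoromethyl would hold on a different core or in microsomes from another species.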